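Swapping methyl for methylsulfanyl on the shared core

The source may hold more compounds than are shown below. What is called first, only, known or untested is meant among the compounds shown, and "the series" means these compounds.

Compound 1 `CCNCC1CCN(c2c(F)cc3c(=O)c(C(=O)O)cn(-c4ccc(F)cc4F)c3c2Cl)C1`: 130 ug/mL
Compound 2 `COc1c(N2CCC(C)(N)C2)c(F)cc2c(=O)c(C(=O)O)cn(C3CC3)c12`: 38 ug/mL
Compound 3 `Cc1c(F)c(N2CCC(N)C2)cc2c1c(=O)c(C(=O)O)cn2C1CC1`: 14 ug/mL

These three values come from a functional assay on V79 cells (Cricetulus griseus) for cytotoxicity, read by colony formation; on this read-out higher numbers stand for weaker inhibition and lower numbers for stronger inhibition. Compound 3 gives the lowest number of the three, 14 ug/mL, and so the strongest inhibition. Both other compounds stand higher, and both gaps lie beyond the usual scatter.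

The next compound to be tested is compound 4 `CSc1c(F)c(N2CCC(N)C2)cc2c1c(=O)c(C(=O)O)cn2C1CC1`. It keeps the structure of compound 3 except at one place, where methylsulfanyl stands in place of methyl on an aromatic carbon, ortho to a fluoro group: methylsulfanyl in place of methyl on an aromatic carbon.

For the measured compounds named here, no two measured compounds differ in only one place, so the data do not show what a single swap like this does in this assay. With so little to go on, the safest expectation is no step beyond the scatter. Compound 3 at 14 ug/mL already sits at the low end of the three numbers, so a small rise seems somewhat more likely than a fall. The expected change is a 1.3-fold higher number from compound 3 to compound 4 (0.11 log units; within the scatter). For compound 4 the estimated value is 18 ug/mL, with an expected range from 6 ug/mL to 55 ug/mL.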

Compound 4, half-maximal inhibitory concentration: 92 ug/mL
For compound 4 the middle estimate is 5.1-fold (0.71 log units) below the measured one; the whole stated range lies below it.
By their numbers in this assay, from the lowest: compound 3; then compound 2; then compounds 4 and 1 (each within the scatter of the next).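

In this assay, methylsulfanyl in place of methyl on an aromatic carbon gives a 6.6-fold higher number from compound 3 to compound 4 (0.82 log units; beyond the scatter), which means weaker inhibition. For the compounds shown here, this is the first pair that differs in only one place, so it is the first direct reading of a single swap: this aromatic carbon, ortho to a fluoro group and ortho to a fused ring, does not tolerate every change without effect, since this one moves the number beyond the scatter. No measurement bearing on why the number rises is available here.

This single pair cannot show whether the rise follows from the sulfur atom or simply from a longer group at this place, and a propyl chain or a bromine atom on the same carbon would help to separate those two readings. It also leaves open whether the same swap would shift the number by a similar amount on compounds with a different amine on the shared core, since the step has been read only between compound 3 and compound 4.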